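Sulfonyl hydrazide series: dichlorophenyl sulfonyl analogue of compound 1

A few compounds are considered here, and "the series" means these few. Any claim that something is new, unique, unknown or untested is made for them only; others in the source may bear on it.

Compound 1 `CC(=O)Nc1ccc(S(=O)(=O)NNC(=O)c2cccnc2Nc2ccc(Cl)cc2)cc1` and compound 2 `O=C(NNS(=O)(=O)c1ccc(F)cc1)c1cccnc1Nc1ccc(Cl)cc1Cl` have been tested in a functional assay on MDA-MB-435 cells (Homo sapiens) for antiproliferative activity; on this read-out higher numbers stand for weaker inhibition of growth and lower numbers for stronger inhibition of growth. In this assay compound 1 gives > 100000 nM, which is a limit of the assay and not a number. Compound 2 likewise gives > 100000 nM, again a limit. For the measured compounds named here, compound 1 therefore stands at the limit of > 100000 nM in this assay, at which 2 of the 2 values shown sit, and no step between measured compounds can be given. Compound 3 `O=C(NNS(=O)(=O)c1ccc(Cl)cc1Cl)c1cccnc1Nc1ccc(Cl)cc1` is the next analogue: the change from compound 1 is 2,4-dichlorophenyl in place of 4-acetamidophenyl on a sulfonyl sulfur. With both measured compounds at the limit, no step beyond the scatter is expected for compound 3. The step of a number no higher from compound 1 to compound 3 (the limit leaves the size open) is expected to be none, and a limit is expected once more. Compound 3 is estimated at 100000 nM, within 30000 nM to 300000 nM.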

Compound 3, concentration for total growth inhibition: 81300 nM
For compound 3 the middle estimate is 1.2-fold (0.09 log units) above the measured one, and the stated range covers the measured number.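

In this assay, for the compounds shown here, compound 3 gives 81300 nM, the only value shown that is a number and not a limit. Placing 2,4-dichlorophenyl in place of 4-acetamidophenyl on a sulfonyl sulfur gives an at least 1.2-fold lower number from compound 1 to compound 3 (0.08 log units; that floor lies within the scatter); the true size of this step stays open and may or may not exceed the usual scatter, but this position can at least carry a group that yields a measurable number. The rest of the series shown stays at the edge of the read-out: the limit of > 100000 nM in this assay, at which 2 of the 3 values shown sit.

Going by these compounds, it remains open whether a single chlorine on the phenyl ring would be enough to give a measurable number. Also open, on these data alone, is how a straight alkyl chain or an aminophenyl group on the sulfonyl sulfur would compare with 2,4-dichlorophenyl.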